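The source may report more compounds than this note shows. Statements on the series, on what has been measured and on what is new or still open speak of the compounds shown alone.

All three measured compounds share one core and differ only in what sits on the amide-type nitrogen. Compound 1 `CNC(=O)CC1CCc2cc(OC)c(OC)cc21` gives 24.1% in a functional assay on the whole organism (strain Wistar) for inhibition, with Rattus norvegicus as the target, read by paw edema, with stated times of 60 min and 6 h, at a dose of 100 mg/kg by the oral route; on this read-out higher numbers stand for more inhibition at the one dose given (going by the name of the read-out) and lower numbers for less inhibition. Compound 2 `CCCCCCNC(=O)CC1CCc2cc(OC)c(OC)cc21` gives 38.3%, and compound 3 `COc1cc2c(cc1OC)C(CC(=O)NC1CCCCC1)CC2` gives 48.2%. The step of a number 14.2 percentage points higher from compound 1 to compound 2 (beyond the scatter) and the step of a number 24.1 percentage points higher from compound 1 to compound 3 (beyond the scatter) both lie beyond the scatter, whereas the step of a number 9.9 percentage points higher from compound 2 to compound 3 (within the scatter) does not. Compound 3 thus shows the highest of the three numbers, though its gap to compound 2 is within the scatter and only its gap to compound 1 is beyond it.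

Compound 4 `COc1cc2c(cc1OC)C(CC(=O)N1CCCCC1)CC2` differs from compound 3 by piperidin-1-yl in place of cyclohexylamino on a carbonyl carbon. Among the measured compounds shown here, every measured step so far kept the amide hydrogen and changed only the carbon group on the nitrogen; none of them bears directly on this change, which removes the one hydrogen-bond donor. For compound 4 the step of a number 8.2 percentage points lower from compound 3 to compound 4 (within the scatter) is therefore expected to stay within the scatter, with a slight lean downward, and its value is estimated at 40%, between 20% and 60%.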

Compound 4, a percentage reported as inhibition, in the whole organism at one dose (the size of the read-out at that dose, not a potency): 31.5%
The estimate for compound 4 lay 8.5 percentage points above the measured number; low and high end bracket the measured number.
By their numbers in this assay, from the lowest: compounds 1, 4, 2 and 3 (each within the scatter of the next, the first and the last beyond it).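

Replacing cyclohexylamino with piperidin-1-yl on the carbonyl carbon keeps a six-membered ring there but removes the amide hydrogen, and it gives a number 16.7 percentage points lower from compound 3 to compound 4 (beyond the scatter). Among the compounds shown here, this is the first change to remove that hydrogen, and it shows that the group at this position can matter even when the ring size stays the same. Compound 4 cannot be ranked against the two open-chain amides, since a number 6.8 percentage points lower from compound 2 to compound 4 (within the scatter) and a number 7.4 percentage points higher from compound 1 to compound 4 (within the scatter) both stay within the scatter, and no evidence to hand explains the step from compound 3.

The loss of the amide hydrogen and the move of the ring onto the nitrogen happen together, so their contributions cannot be separated. An amide nitrogen carrying both cyclohexyl and methyl would keep the carbon ring without the hydrogen, and morpholin-4-yl would test another ring in place of piperidin-1-yl.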